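Swapping a Furan for a Pyrazole on the Shared Core

The compounds below may be only part of what the source reports. "The series", "measured", "known", "first", "only" and "open" are said of these compounds alone.

Values in a functional assay on CWR22R cells (Homo sapiens) for antiproliferative activity, read by CCK-8 assay, with a stated time of 6 days; a lower number here means a stronger inhibitor, a higher number a weaker inhibitor:
- Compound 1 `Cc1noc(C)c1-c1cccc(Oc2ccc(C#N)c(C(F)(F)F)c2)c1`: "not determined" (no result reported)
- Compound 2 `CCN(c1ccc(C#N)c(Cl)c1)c1cc(-n2cnc3ccccc32)ccc1C`: 3040 nM
- Compound 3 `CCN(c1ccc(C#N)c(Cl)c1)c1cc(-c2ccco2)ccc1C`: > 30000 nM

The entry for compound 3 is a limit of the assay and not a number. Compound 4 `CCN(c1ccc(C#N)c(Cl)c1)c1cc(-c2ccnn2C)ccc1C` is still unmeasured, and its difference is 1-methyl-1H-pyrazol-5-yl in place of furan-2-yl on an aromatic carbon. Among the compounds with values here, only one measured step bears on this carbon: an at least 9.8-fold higher number from compound 2 to compound 3 (0.99 log units; beyond the scatter), which lies beyond the scatter. The group here can therefore matter, but compound 2 carries a different kind of group from compound 4. Both the leaving and the entering group are one five-membered aromatic ring, so only a modest move towards a lower number is expected in this assay, an estimated at least 2.0-fold lower number from compound 3 to compound 4 (0.30 log units; that floor lies within the scatter). Compound 4 is expected at 15000 nM, with an estimated range of 4000 nM to 40000 nM.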

Compound 4, half-maximal inhibitory concentration: 4330 nM
Beside the measured number, compound 4's estimate is 3.5-fold (0.54 log units) above it; the range from low to high includes it.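

Two groups that are each one five-membered aromatic ring are not interchangeable on this carbon: this assay shows an at least 6.9-fold lower number from compound 3 to compound 4 (0.84 log units; beyond the scatter). The entry for compound 3 is a limit of the assay and not a number: the limit of > 30000 nM in this assay, at which 1 of the 4 values shown sits. Swapping the 1H-benzimidazol-1-yl group for 1-methyl-1H-pyrazol-5-yl gives a 1.4-fold higher number from compound 2 to compound 4 (0.15 log units; within the scatter), so these two groups cannot be told apart here.

The furan-to-pyrazole change alters the ring atoms and adds a methyl group at once, and the compounds shown cannot separate the two. Going by these compounds, how an amine or a carboxylic acid on this carbon would fare remains open.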